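A Hydroxy Group Added to a Chlorinated Triarylmethanol

This account rests on a few compounds, and the source may have more. Where it says the series, first, only, none or still open, it means among the compounds named here.

Going by the values given here, compound 1 `OC(c1ccccc1)(c1ccccc1)c1ccccc1Cl` gives 31% in a functional assay on NIH3T3 cells (Mus musculus) for inhibition, tested at 10 uM (a lower number here means less inhibition, a higher number more inhibition at the concentration tested (going by the name of the read-out)), the only number recorded for it, alongside one further entry that carries no single number. Compound 2 `Oc1ccccc1C(O)(c1ccccc1)c1ccccc1`, itself bearing a hydroxy group, gives 99%; 99% (2 entries) in this assay in two separate entries. Compound 3 `Oc1ccccc1C(O)(c1ccccc1)c1ccccc1Cl` has not yet been measured. It differs from compound 1 by hydroxy in place of hydrogen on an aromatic carbon. The step is expected to be large and upward, beyond the usual scatter, because compound 2 gives 99%; 99% (2 entries). In this assay the expected step is a number 54 percentage points higher from compound 1 to compound 3 (beyond the scatter). Compound 3 is therefore estimated to reach about 85%, between 55% and 99%.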

Compound 3, a percentage reported as inhibition, at one concentration (the size of the read-out at that concentration, not a potency): 99%
Compound 3: middle estimate off by 14 percentage points, on the low side; low and high end bracket the measured number.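

In this assay, hydroxy in place of hydrogen on the aromatic carbon ortho to a large group brings a number 68 percentage points higher from compound 1 to compound 3 (beyond the scatter) on the chlorinated core, a large step. Going by these compounds alone, until now, no pair of compounds differing in one place had isolated this change. Nothing shown explains why the step is so large.

The compounds leave open whether a methoxy or an amine at this position would produce a similar step. They also leave open how compound 3 ranks at lower concentrations, since its reading is at a single concentration.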